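Hemolysis series: aminopropyl versus guanidine-bearing amide side chain

The source may report more compounds than this note shows. Statements on the series, on what has been measured and on what is new or still open speak of the compounds shown alone.

Compound 1 `CC(C)(C)c1ccc(CC(CN)(Cc2ccc(C(C)(C)C)cc2)C(=O)NCCCN)cc1` and compound 2 `NCCCNC(=O)C(CN)(Cc1ccc(C(F)(F)F)cc1)Cc1ccc(C(F)(F)F)cc1` share an amide-linked 3-aminopropyl group; the difference between their two cores is not broken down here. In an ADME assay on cells (Erythrocyte, Homo sapiens), read by hemolysis (a higher number here means that more compound is needed for the effect, a lower number that less compound is needed), compound 1 gives 254000 nM. In this assay compound 2 gives 790000 nM, the higher of the two measured numbers, a step from compound 1 that lies beyond the scatter.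

Compound 3 `CC(C)(C)c1ccc(CC(CN)(Cc2ccc(C(C)(C)C)cc2)C(=O)N[C@@H](CCCNC(=N)N)C(N)=O)cc1` carries the change (a group of 11 heavy atoms (6 carbon, 4 nitrogen, 1 oxygen; no ring) in place of a group of 4 heavy atoms (3 carbon, 1 nitrogen; no ring), on an amide-type nitrogen). For compound 3 in this assay only a limit is reported, > 654000 nM. The step of an at least 2.5-fold higher number from compound 1 to compound 3 (0.41 log units; beyond the scatter) therefore rests on a limit of > 654000 nM in this assay, at which 1 of the 3 values shown sits, and its full size is not known.

Compound 4 `N=C(N)NCCC[C@H](NC(=O)C(CN)(Cc1ccc(C(F)(F)F)cc1)Cc1ccc(C(F)(F)F)cc1)C(N)=O` is not yet measured in this assay. It arises from compound 2 by a group of 11 heavy atoms (6 carbon, 4 nitrogen, 1 oxygen; no ring) in place of a group of 4 heavy atoms (3 carbon, 1 nitrogen; no ring), on an amide-type nitrogen, the same change as from compound 1 to compound 3, at the same place. The step of an at least 2.5-fold higher number from compound 1 to compound 3 (0.41 log units; beyond the scatter) points to a higher number for compound 4 than for compound 2. Compound 2 already stands at 790000 nM in this assay. The reading for compound 4 may then itself come back as a limit. For compound 4 in this assay a step of a 2.5-fold higher number from compound 2 to compound 4 (0.40 log units; beyond the scatter) is expected. Compound 4 is estimated to give 2000000 nM in this assay, between 800000 nM and 5000000 nM, quite possibly reported only as a limit.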

Compound 4, half-maximal effective concentration: 990000 nM
Compound 4: middle estimate off by 2.0-fold (0.31 log units), on the high side, within the range that was stated.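

In this assay, on the core of compound 2, replacing the 3-aminopropyl group on the amide-type nitrogen with the larger guanidine-bearing side chain gives a 1.3-fold higher number from compound 2 to compound 4 (0.10 log units; within the scatter), so on this core the change cannot be told apart from repeat-measurement noise. Set beside the same change on the core of compound 1, the two steps read as follows: the same change on two cores in this assay, an at least 2.5-fold higher number (0.41 log units; beyond the scatter) from compound 1 to compound 3 and a 1.3-fold higher number (0.10 log units; within the scatter) from compound 2 to compound 4; the limit leaves it open whether they differ. The notes therefore do not establish that the change carries over from one core to the other with the same size, nor that its size depends on the core, and the reading for compound 3 is a limit, not a number: the limit of > 654000 nM in this assay, at which 1 of the 4 values shown sits.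

A numerical reading for compound 3 would decide whether the two steps differ, and a third core would test whether any pattern holds beyond these two pairs. Also open, as far as these compounds go, is how this assay would read on either core with a carboxylic acid in place of the terminal carboxamide, or with a shorter or longer chain ending in an amine or a guanidine.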